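Flipping One Double Bond in a Phenolic Terpenoid

This account rests on a few compounds, and the source may have more. Where it says the series, first, only, none or still open, it means among the compounds named here.

Compound 1 `C/C(=C/CC/C(C)=C/CC/C(C)=C\C(=O)C/C(C)=C/Cc1cc(O)cc(C)c1O)CO` gives 6.8 ug/mL in a functional assay on HepG2 cells (Homo sapiens) for cytotoxicity; a lower number here means a stronger inhibitor of growth, a higher number a weaker inhibitor of growth.
Compound 2 `C/C(=C\C(=O)C/C(C)=C/Cc1cc(O)cc(C)c1O)CC/C=C(\C)Cc1cc(C)co1` gives 1.8 ug/mL in this assay.

Of the two measured compounds, compound 2 has the lower number in this assay, and the gap to compound 1 lies beyond the usual scatter, so compound 2 is the stronger growth inhibitor of the pair. Compound 3 `C/C(=C/C(=O)C/C(C)=C/Cc1cc(O)cc(C)c1O)CC/C=C(\C)Cc1cc(C)co1` has not yet been measured. Its relation to compound 2 is simple: the two compounds have the same atoms and bonds and differ only in configuration as drawn: 1 of 3 stereo elements differ; a double bond is drawn E in compound 2 and Z in compound 3. Among the measured compounds shown here, no measured pair here shows the effect of redrawing a double bond from E to Z, so the size of the step is uncertain. Such a change often moves the number only a little, in either direction, and a step within the scatter seems most likely. Compound 3 is therefore expected to land near 2.5 ug/mL, within 1 ug/mL to 6 ug/mL, an expected step of a 1.4-fold higher number from compound 2 to compound 3 (0.14 log units; within the scatter).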

Compound 3, concentration for 50% growth inhibition: 1.7 ug/mL
Beside the measured number, compound 3's estimate is 1.5-fold (0.17 log units) above it; low and high end bracket the measured number.
By their numbers in this assay, from the lowest: compounds 3 and 2 (each within the scatter of the next); then compound 1.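

Redrawing this one double bond from E to Z gives a 1.1-fold lower number from compound 2 to compound 3 (0.02 log units; within the scatter) in this assay, so this assay detects no effect of the drawn geometry at this position, in the one pair available. The comparison is a clean one, with nothing else to account for the result: the fact that compounds 2 and 3 differ only in the configuration as drawn. The change at the far end of the chain, 4-methylfuran-2-yl in place of 3-(hydroxymethyl)but-2-en-1-yl, gives a 4.0-fold lower number from compound 1 to compound 3 (0.60 log units; beyond the scatter), a step that stands out against the flat result of the double-bond change.

Still open, from the compounds shown here alone, is whether the other double bonds in the chain would tolerate the same redrawing, or whether this one would with 3-(hydroxymethyl)but-2-en-1-yl in place of 4-methylfuran-2-yl. Also open, going by these compounds, is how a carboxylic acid or an amine at the end of the chain would compare with 4-methylfuran-2-yl.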